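A few compounds are considered here, and "the series" means these few. Any claim that something is new, unique, unknown or untested is made for them only; others in the source may bear on it.

Measured compounds in a functional assay on SF-268 cells (Homo sapiens) for cytotoxicity, read by sulforhodamine B assay, with a stated time of 48 h; on this read-out lower numbers stand for stronger inhibition of growth and higher numbers for weaker inhibition of growth:

Compound 1, `ClCc1ccccc1Cn1cnc2c(Cl)nc(Cl)nc21`, gives 1770 nM.
Compound 2, `ClCc1ccccc1Cn1cnc2c(Cl)ncnc21`, gives 3230 nM.
Compound 3, `ClCc1cccc(Cn2cnc3c(Cl)nc(Cl)nc32)c1`, gives 2510 nM.

Compound 2 has the highest of the three numbers in this assay, though its gaps to compound 3 and to compound 1 both lie within the scatter, so no order among the three can be claimed. Compound 4, `Nc1nc(Cl)c2ncn(Cc3ccccc3CCl)c2n1`, has not been measured; it differs from compound 2 by amino in place of hydrogen on an aromatic carbon.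

Within the data shown here, the only measured step that bears on this is the change at the same aromatic carbon: a 1.8-fold higher number from compound 1 to compound 2 (0.26 log units; within the scatter). Among the measured compounds shown here, that step stayed within the scatter, so the one precedent at this position shows only a small effect of swapping the substituent there. For the measured compounds named here, no measured pair shows an amino group, so the direction of the new step rests on nothing beyond that precedent. Compound 4 is therefore expected to land close to compound 2, with a 1.3-fold lower number from compound 2 to compound 4 (0.11 log units; within the scatter) as the estimated step, and its value in this assay is estimated at 2500 nM, within a range from 800 nM to 8000 nM.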

Compound 4, concentration for 50% growth inhibition: 4680 nM
Beside the measured number, compound 4's estimate is 1.9-fold (0.27 log units) below it, within the range that was stated.
By their numbers in this assay, from the lowest: compounds 1, 3, 2 and 4 (each within the scatter of the next, the first and the last beyond it).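

In this assay, amino in place of hydrogen on the aromatic carbon between two ring nitrogen atoms gives a 1.4-fold higher number from compound 2 to compound 4 (0.16 log units; within the scatter) and so cannot be told apart from hydrogen at this position. Amino in place of chloro at the same carbon gives a 2.6-fold higher number from compound 1 to compound 4 (0.42 log units; beyond the scatter) and is the first change here to pass beyond the scatter, though only modestly. Chloro and amino are thus the one pair of groups at this position that can be told apart, while hydrogen lies within the scatter of both.

On these data alone, whether a larger group on this carbon, such as methoxy or dimethylamino, would move the number further remains open, as does whether amino would have the same effect on the core of compound 3. No measurement shown here accounts for the size of these steps.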